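A few compounds are considered here, and "the series" means these few. Any claim that something is new, unique, unknown or untested is made for them only; others in the source may bear on it.

Compound 1, whose structure is `CC(C(=O)NCc1ccc(C(F)(F)F)nc1NCc1cccnc1)c1ccc(NS(C)(=O)=O)c(F)c1`, gave no number in a functional assay on CHO-K1 cells for antagonist activity at transient receptor potential cation channel subfamily V member 1 (Homo sapiens), read by FLIPR; on this read-out higher numbers stand for weaker inhibition and lower numbers for stronger inhibition: its result there was reported only as "not active" (no number reported), so compound 1 stands at no measured point on that scale. Two close relatives of compound 1 show what the shared core can reach in this assay. Compound 2, `CC1CCCN1c1nc(C(F)(F)F)ccc1CNC(=O)[C@@H](C)c1ccc(NS(C)(=O)=O)c(F)c1`, gives 0.3 nM in this assay. Compound 3, `C[C@H](C(=O)NCc1ccc(C(F)(F)F)nc1N1CC[C@@H](OCc2ccccc2)C1)c1ccc(NS(C)(=O)=O)c(F)c1`, gives 1.4 nM in this assay. Both are strong inhibitors on this read-out, while compound 1 is not.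

Compound 4, `CC(C(=O)NCc1ccc(C(F)(F)F)nc1N1CCN(C2CCCCC2)CC1)c1ccc(NS(C)(=O)=O)c(F)c1`, is the next member. It differs from compound 1 in one place: 4-cyclohexylpiperazin-1-yl in place of ((pyridin-3-yl)methyl)amino on an aromatic carbon. The group that enters is a 4-cyclohexylpiperazin-1-yl, taking the place of the ((pyridin-3-yl)methyl)amino on an aromatic carbon next to the ring nitrogen of the core.

Among the compounds with values here, no measured step connects compound 1 to any other compound, so the size of the change cannot be read from a pair. Because compound 1 shows "not active" (no number reported) and compounds 2 and 3 show strong inhibition, compound 4 is expected to move far beyond the scatter toward stronger inhibition, in the direction of compounds 2 and 3, though with a real chance that it, too, is reported as not active. Compound 4 is expected to give 5 nM in this assay, with a likely range from 0.5 nM to 50 nM.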

Compound 4, inhibition constant: 21.6 nM
Compound 4: middle estimate off by 4.3-fold (0.64 log units), on the low side; the range from low to high includes it.
By their numbers in this assay, from the lowest: compound 2; then compound 3; then compound 4.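

In this assay compound 4 gives 21.6 nM, yet no step can be read from this result, as compound 1 carries no number and neither compound 2 nor compound 3 forms a listed step with compound 4. No evidence on the cause of this result is available. The compounds shown leave open how large the change from compound 1 to compound 4 actually is.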